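The source may hold more compounds than are shown below. What is called first, only, known or untested is meant among the compounds shown, and "the series" means these compounds.

Measured:
compound 1 `COc1ccc(C(=O)/C=C/c2cc(-c3cc(OC)c(OC)c(OC)c3)n3nc(-c4ccccc4)cc3n2)cc1`: 13200 nM
compound 2 `COc1ccc(-c2cc(/C=C/C(=O)c3ccc(C)c(C)c3)nc3cc(-c4ccccc4)nn23)cc1OC`: 11500 nM

In a functional assay on MDA-MB-231 cells (Homo sapiens) for antiproliferative activity, read by MTT assay, with a stated time of 24 h (a higher number here means a weaker inhibitor, a lower number a stronger inhibitor), compound 2 gives the lowest of the two numbers shown, with compound 1 within the scatter of it. Compound 3 `COc1cc(-c2cc(/C=C/C(=O)c3ccc(C)c(C)c3)nc3cc(-c4ccccc4)nn23)cc(OC)c1OC` differs from compound 2 by methoxy in place of hydrogen on an aromatic carbon. For the measured compounds named here, no step between measured compounds covers this change; compound 1, which already carries a 3,4,5-trimethoxyphenyl group but differs elsewhere, gives a number close to that of compound 2. The step is expected to stay within the scatter, a 1.2-fold lower number from compound 2 to compound 3 (0.06 log units; within the scatter). Compound 3 is estimated at 10000 nM, with a range from 4000 nM to 25000 nM.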

Compound 3, half-maximal inhibitory concentration: 13500 nM
Estimate against measurement, compound 3: 1.4-fold (0.13 log units) below; measured number inside the range.
By their numbers in this assay, from the lowest: compounds 2, 1 and 3 (each within the scatter of the next).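

In this assay, 3,4,5-trimethoxyphenyl in place of 3,4-dimethoxyphenyl gives a 1.2-fold higher number from compound 2 to compound 3 (0.07 log units; within the scatter), so this position takes the added methoxy without a step beyond the scatter. For the compounds shown here, at the carbonyl carbon, 3,4-dimethylphenyl in place of 4-methoxyphenyl gives a 1.0-fold higher number from compound 1 to compound 3 (0.01 log units; within the scatter), which is the first reading of that exchange with the 3,4,5-trimethoxyphenyl group held fixed. No measurement offered here explains either result.

The compounds shown leave open whether an amine or a longer chain such as butoxy at this position would move the number beyond the scatter. The same question stands for a carboxylic acid on the phenyl group at the carbonyl carbon.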